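Chloropyridinyl exchange on the carbonyl: compound 3 to compound 4

A few compounds are considered here, and "the series" means these few. Any claim that something is new, unique, unknown or untested is made for them only; others in the source may bear on it.

Measured in a functional assay on WM 266-4 cells (Homo sapiens) for antiproliferative activity, read by MTT assay, with a stated time of 24 h (a lower number here means a stronger inhibitor of growth, a higher number a weaker inhibitor of growth), so far
compound 1 `COc1ccc(C2=NN(C(=O)c3cccnc3Cl)C(c3ccc(OC)cc3)C2)cc1` gives 4350 nM
compound 2 `COc1ccc(C2=NN(C(=O)c3cccnc3Cl)C(c3ccc(Cl)cc3)C2)cc1` gives 780 nM
compound 3 `COc1ccc(C2=NN(C(=O)c3ccc(Cl)nc3)C(c3ccc(Br)cc3)C2)cc1` gives 7130 nM

Compound 3 lies within the scatter of compound 1 and beyond the scatter of compound 2. Compound 4 `COc1ccc(C2=NN(C(=O)c3cccnc3Cl)C(c3ccc(Br)cc3)C2)cc1` differs from compound 3 by 2-chloropyridin-3-yl in place of 6-chloropyridin-3-yl on a carbonyl carbon (same atoms, joined differently). For the measured compounds named here, no measured step isolates this exchange. Going by the values given here, the only step (a 5.6-fold lower number from compound 1 to compound 2 (0.75 log units; beyond the scatter)) changes another place, and both its compounds carry 2-chloropyridin-3-yl, as compound 4 does. The expectation therefore leans toward compound 2 (780 nM) and remains uncertain. A lower number, beyond the scatter, is expected (a 6.5-fold lower number from compound 3 to compound 4 (0.81 log units; beyond the scatter)). The estimate for compound 4 is 1100 nM (expected range 400 nM to 3500 nM).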

Compound 4, concentration for 50% growth inhibition: 3050 nM
Compound 4: the middle estimate sits 2.8-fold (0.44 log units) below what was measured; the measured number falls inside the stated range.
By their numbers in this assay, from the lowest: compound 2; then compounds 4, 1 and 3 (each within the scatter of the next, the first and the last beyond it).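

The placement of the chlorine on the pyridine attached to the carbonyl carbon registers in this assay: 2-chloropyridin-3-yl in place of 6-chloropyridin-3-yl gives a 2.3-fold lower number from compound 3 to compound 4 (0.37 log units; beyond the scatter). With 2-chloropyridin-3-yl held, bromo in place of chloro on the aromatic carbon gives a 3.9-fold higher number from compound 2 to compound 4 (0.59 log units; beyond the scatter), so the two halogens are distinguished here. Bromo in place of methoxy gives a 1.4-fold lower number from compound 1 to compound 4 (0.15 log units; within the scatter), so bromo does not share the lower number seen with chloro.

No available data explain these differences. On these data alone, whether the isomer step holds with chloro or methoxy in place of bromo remains open, as does how an amine or a carboxylic acid at that aromatic carbon would read.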